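Changing the Group on a Carbonyl Carbon

The compounds below may be only part of what the source reports. "The series", "measured", "known", "first", "only" and "open" are said of these compounds alone.

In a physicochemical assay for solubility, read by HPLC, in phosphate buffer, measured as kinetic solubility, at pH 7.4 (on this read-out higher numbers stand for higher solubility and lower numbers for lower solubility), compound 1 `CC(C)(C)C(=O)c1cc(-c2ccc(S(N)(=O)=O)cc2)n(-c2ccc(Cl)cc2)n1` gives 6600 nM, compound 2 `NS(=O)(=O)c1ccc(-c2cc(C(=O)C3CCCC3)nn2-c2ccc(Cl)cc2)cc1` gives 4600 nM and compound 3 `NS(=O)(=O)c1ccc(-c2cc(C(=O)CC3CCCC3)nn2-c2ccc(Cl)cc2)cc1` gives 2600 nM. Compound 3 thus stands clearly apart only from compound 1, with a 2.5-fold lower number from compound 1 to compound 3 (0.40 log units; beyond the scatter), while a 1.8-fold lower number from compound 2 to compound 3 (0.25 log units; within the scatter) and a 1.4-fold lower number from compound 1 to compound 2 (0.16 log units; within the scatter) are both small. Compound 4 `NS(=O)(=O)c1ccc(-c2cc(C(=O)NN3CCCCC3)nn2-c2ccc(Cl)cc2)cc1` carries (piperidin-1-yl)amino in place of cyclopentylmethyl on a carbonyl carbon. The three measured steps changed this same place, but only among groups of carbon, so they are a loose guide to a group containing nitrogen. The largest of them was modest, so the expected change in this assay is a 1.2-fold higher number from compound 3 to compound 4 (0.09 log units; within the scatter), none beyond the scatter. For compound 4 the estimated value is 3200 nM, within a range of 1100 nM to 9000 nM.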

Compound 4, solubility: 53700 nM
Compound 4: middle estimate off by 17-fold (1.22 log units), on the low side; measured number above the stated range.
By their numbers in this assay, from the lowest: compounds 3, 2 and 1 (each within the scatter of the next, the first and the last beyond it); then compound 4.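

Among groups of carbon, this place barely moved the number in this assay, but the change to (piperidin-1-yl)amino gives a 21-fold higher number from compound 3 to compound 4 (1.32 log units; beyond the scatter) and a 12-fold higher number from compound 2 to compound 4 (1.07 log units; beyond the scatter) and an 8.1-fold higher number from compound 1 to compound 4 (0.91 log units; beyond the scatter) in turn. The position can therefore shift this read-out much further than the carbon groups alone showed, and all three of them lie on the same side of compound 4. Nothing shown here explains the rise. Still open, from the compounds shown here alone, is which part of the change matters, as the ring and the nitrogen atoms enter together. A cyclopentylamino group or a piperidine amide on the same carbonyl carbon would begin to separate them.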